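The source may report more compounds than this note shows. Statements on the series, on what has been measured and on what is new or still open speak of the compounds shown alone.

Compound 1 `COc1ccc(C(=O)c2ccc3c(c2)C=CC(C)(C)O3)c(NC(=O)CO)c1` and compound 2 `COc1ccc(C(=O)c2ccc3c(c2)C=CC(C)(C)O3)c(NC(=O)CN)c1` share one core; compound 3 `C=C(c1cc(OC)c(OC)c(OC)c1)c1ccc(OC)cc1NC(=O)CO` and compound 4 `C=C(c1cc(OC)c(OC)c(OC)c1)c1ccc(OC)cc1NC(=O)CN` share another, and the difference between the two cores is not broken down here. In a functional assay on MCF7 cells (Homo sapiens) for antiproliferative activity, read by MTT assay, with a stated time of 48 h (a lower number here means a stronger inhibitor, a higher number a weaker inhibitor), compound 1 gives 200 nM, while compound 2 gives 680 nM. The change between them, (amino in place of hydroxy on a saturated chain carbon bound to a carbonyl carbon), made a 3.4-fold higher number from compound 1 to compound 2 (0.53 log units; beyond the scatter). Compound 3 gives 110 nM, which lies within the scatter of compound 1. Compound 4 carries the same change on the core of compound 3, namely (amino in place of hydroxy on a saturated chain carbon bound to a carbonyl carbon). Among the measured compounds shown here, the earlier step, from compound 1 to compound 2, is the only guide, so compound 4 is expected to show a step of about the same size, a 3.4-fold higher number from compound 3 to compound 4 (0.53 log units; beyond the scatter), because compound 3 stands at 110 nM. Compound 4 is therefore estimated at 370 nM, most likely between 150 nM and 900 nM.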

Compound 4, half-maximal inhibitory concentration: 190 nM
Estimate against measurement, compound 4: 1.9-fold (0.29 log units) above; low and high end bracket the measured number.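

In this assay, putting amino in place of hydroxy on the second core gives a 1.7-fold higher number from compound 3 to compound 4 (0.24 log units; within the scatter). Set beside the earlier step, the two readings do not differ by more than repeated measurements would: the same change on two cores in this assay, a 3.4-fold higher number (0.53 log units; beyond the scatter) from compound 1 to compound 2 and a 1.7-fold higher number (0.24 log units; within the scatter) from compound 3 to compound 4, 2.0-fold (0.29 log units) apart, within the scatter of two such steps. As far as these two pairs go, the change carries from one core to the other without a detectable difference in step size, but this does not establish a fixed step size, and it says nothing about any other core.

The compounds shown leave open how a dimethylamino group, a carboxylic acid or a longer chain ending in amino or hydroxy would read on either core. They also leave open whether the amide hydrogen matters to the step.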